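The compounds below may be only part of what the source reports. "The series", "measured", "known", "first", "only" and "open" are said of these compounds alone.

Measured compounds:
- Compound 1 `COC(=O)c1ccccc1OCc1cn(-c2ccc(S(=O)(=O)N3CCc4ccccc4C3)cc2)nn1`: 630 nM
- Compound 2 `O=c1cc(OCc2cn(-c3ccc(S(=O)(=O)N4CCc5ccccc5C4)cc3)nn2)c2ccccc2o1`: 24800 nM

In a functional assay on HuCC-A1 cells (Homo sapiens) for cytotoxicity, read by MTT assay, with a stated time of 48 h (a higher number here means a weaker inhibitor, a lower number a stronger inhibitor), compound 1 gives 630 nM, and compound 2 gives 24800 nM. Compound 2 thus stands as the weaker of the two measured compounds, with the higher number of the pair. Going by the values given here, the only measured step is a 39-fold higher number from compound 1 to compound 2 (1.60 log units; beyond the scatter), showing that swapping one group for another on the oxygen on a saturated carbon moved the number a long way.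

Compound 3 `O=S(=O)(c1ccc(-n2cc(CO)nn2)cc1)N1CCc2ccccc2C1` has not yet been measured in this assay. It differs from compound 2 by a hydrogen atom in place of a group of 11 heavy atoms (9 carbon, 2 oxygen; one six-membered aromatic ring of carbon only, one six-membered aromatic ring with 1 hetero atom), on an oxygen on a saturated carbon: the oxygen is left bearing only a hydrogen, so the arm that carried the two rings is gone altogether. Among the compounds with values here, the one known step bears on this only loosely, since it compares two ring-bearing groups rather than a group against a bare hydrogen; its size shows the site is sensitive, but not which way removal will go.

The expectation is a step of a 1.2-fold higher number from compound 2 to compound 3 (0.08 log units; within the scatter), of modest size and uncertain direction. Compound 3 is estimated at 30000 nM, within a range of 8000 nM to 100000 nM.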

Compound 3, half-maximal inhibitory concentration: 51400 nM
Beside the measured number, compound 3's estimate is 1.7-fold (0.23 log units) below it, within the range that was stated.
By their numbers in this assay, from the lowest: compound 1; then compound 2; then compound 3.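

Removing the whole arm so that the oxygen on a saturated carbon carries only hydrogen gives a reference point for this position, and the change is modest, with a 2.1-fold higher number from compound 2 to compound 3 (0.32 log units; beyond the scatter) in this assay. Set against that, an 82-fold higher number from compound 1 to compound 3 (1.91 log units; beyond the scatter) is large, so the two groups on this oxygen are far from equal: 2-(methoxycarbonyl)phenyl goes with a much lower number, while the two-ring group of compound 2 improves only modestly on a bare hydrogen, which shows that a large ring-bearing group at this position does not by itself bring a low number. No accompanying measurement explains why these groups differ so widely.

From the compounds shown here alone, it remains open whether the low number of compound 1 depends on the methoxycarbonyl group or on the benzene ring that carries it, a question that a plain phenyl on the oxygen, or a carboxylic acid in place of the methoxycarbonyl, would address. Also open, going by these compounds, is where a small group on this oxygen would fall, such as a methyl or a short chain ending in an amine, relative to hydrogen and 2-(methoxycarbonyl)phenyl.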